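A Benzoyl Swap on the Top-Exposure Compound

The compounds below may be only part of what the source reports. "The series", "measured", "known", "first", "only" and "open" are said of these compounds alone.

Compound 1 `Cc1cc(C)c(NC(=O)c2sccc2S(=O)(=O)Nc2onc(C)c2Cl)c(C)c1`: 81600 nM
Compound 2 `Cc1cc(C)c(NS(C)(=O)=O)c(C)c1NC(=O)c1sccc1S(=O)(=O)Nc1onc(C)c1Cl`: 5250 nM

In an in vivo ADME assay on the whole organism (plasma) for pharmacokinetics, with Rattus norvegicus as the target, at a dose of 50 mg/kg by the oral route (on this read-out higher numbers stand for higher exposure at the dose given and lower numbers for lower exposure), compound 1 stands highest of the two measured compounds, at 81600 nM. Compound 3 `Cc1cc(C)c(NC(=O)c2sccc2S(=O)(=O)Nc2onc(C)c2Cl)c(C(=O)c2ccccc2)c1` has benzoyl in place of methyl on an aromatic carbon. Within the data shown here, only one measured step bears on this, and only loosely, since it is a different change: methanesulfonamido in place of hydrogen on an aromatic carbon gave a 16-fold lower number from compound 1 to compound 2 (1.19 log units; beyond the scatter), which lies beyond the scatter. A smaller fall in this assay is expected here, an estimated 3.3-fold lower number from compound 1 to compound 3 (0.51 log units; beyond the scatter). Compound 3 is expected to reach 25000 nM, with an estimated range of 6000 nM to 80000 nM.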

Compound 3, maximal plasma concentration: 63100 nM
Compound 3: middle estimate off by 2.5-fold (0.40 log units), on the low side, within the range that was stated.
By their numbers in this assay, from the lowest: compound 2; then compounds 3 and 1 (each within the scatter of the next).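

In this assay, benzoyl in place of methyl on an aromatic carbon gave a 1.3-fold lower number from compound 1 to compound 3 (0.11 log units; within the scatter) and so a far larger group, bringing a six-membered aromatic ring and a hydrogen-bond acceptor, was carried at this position with no change that stands clear of the scatter. The large fall seen earlier, a 16-fold lower number from compound 1 to compound 2 (1.19 log units; beyond the scatter), came from a different change and says nothing about this place. Nothing measured here gives a reason for this result. On these data alone, whether an amine or a carboxylic acid on this same carbon would also leave the number within the scatter remains open.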